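Swapping One Group on a Weakly Active Series

The compounds below may be only part of what the source reports. "The series", "measured", "known", "first", "only" and "open" are said of these compounds alone.

Measured in a functional assay on NCI-H460 cells (Homo sapiens) for antiproliferative activity, read by trypan blue exclusion, with a stated time of 24 h; a higher number here means a weaker inhibitor, a lower number a stronger inhibitor:
- Compound 1 `O=C1NC(=O)/C(=C/c2cn(Cc3ccc([N+](=O)[O-])cc3)c3ccccc23)N1`: > 40000 nM, which is a limit of the assay and not a number
- Compound 2 `O=C1NC(=O)/C(=C/c2cn(Cc3ccc(Cl)cc3)c3ccccc23)N1`: 25400 nM
- Compound 3 `COC(=O)c1ccc(Cn2cc(/C=C3\NC(=O)NC3=O)c3ccccc32)cc1`: 30800 nM

These three compounds share one core and differ in a single group. Only compound 2 and compound 3 have true numbers, and the two cannot be told apart, as a 1.2-fold higher number from compound 2 to compound 3 (0.08 log units; within the scatter) shows. Compound 3 therefore stands level with compound 2.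

The next compound is compound 4 `O=C1NC(=O)/C(=C/c2cn(Cc3ccc(F)cc3)c3ccccc23)N1`, which carries fluoro in place of methoxycarbonyl on an aromatic carbon. Among the measured compounds shown here, no measured compound has fluoro, so the guidance is indirect. Changing this same group has so far produced only small steps. Chloro in place of nitro gives an at least 1.5-fold lower number from compound 1 to compound 2 (0.19 log units; that floor lies within the scatter), and methoxycarbonyl in place of nitro gives an at least 1.2-fold lower number from compound 1 to compound 3 (0.11 log units; that floor lies within the scatter). Both of these steps rest on the limit of compound 1. For the measured compounds named here, the one step between true numbers, a 1.2-fold higher number from compound 2 to compound 3 (0.08 log units; within the scatter), also stays within the scatter.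

In this assay, no change beyond the scatter is therefore expected. The estimated step is a 1.2-fold lower number from compound 3 to compound 4 (0.07 log units; within the scatter). The expected value for compound 4 is 26000 nM, with an estimated range of 14000 nM to 40000 nM.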

Compound 4, half-maximal inhibitory concentration: 16300 nM
Beside the measured number, compound 4's estimate is 1.6-fold (0.20 log units) above it; the range from low to high includes it.
By their numbers in this assay, from the lowest: compounds 4, 2 and 3 (each within the scatter of the next). At a limit, above all of these: compound 1.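

In this assay, among the compounds shown here, fluoro on this aromatic carbon, para to a large group, gives the first step that is printed as beyond the scatter: an at least 2.4-fold lower number from compound 1 to compound 4 (0.38 log units; beyond the scatter). That step is only a floor, since compound 1 stands at a limit and not at a number: the limit of > 40000 nM in this assay, at which 1 of the 4 values shown sits. Among the true numbers, the picture stays flat, with a 1.9-fold lower number from compound 3 to compound 4 (0.28 log units; within the scatter) and a 1.6-fold lower number from compound 2 to compound 4 (0.19 log units; within the scatter), so even exchanging methoxycarbonyl, with its 4 heavy atoms, for fluoro, with 1, does not separate compound 4 from compound 3 or compound 2 at this position.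

The compounds shown leave open whether an amine, a carboxylic acid or a hydroxyl group on this same carbon would bring a change beyond the scatter among true numbers. They also leave open what a longer chain in place of these groups would do, and whether any group here could bring the activity far below the values of compound 2, compound 3 and compound 4.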